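The source may hold more compounds than are shown below. What is called first, only, known or untested is meant among the compounds shown, and "the series" means these compounds.

Three members of the series have been measured in a functional assay on SW480 cells (Homo sapiens) for cytotoxicity, read by MTT assay, with a stated time of 4 days; a higher number here means a weaker inhibitor, a lower number a stronger inhibitor: compound 1 `Cc1ccc(S(=O)(=O)Oc2ccc3c(c2C)[C@H](Cn2cc(-c4ccccc4)nn2)[C@@]24CC(=O)[C@@](C)(CC[C@@H]32)C4)cc1`, compound 2 `Cc1c(O)ccc2c1[C@H](Cn1cc(-c3ccc(Cl)cc3)nn1)[C@@]13CC(=O)[C@@](C)(CC[C@@H]21)C3` and compound 3 `COc1ccc(-c2cn(C[C@H]3c4c(ccc(OS(=O)(=O)c5ccc(C)cc5)c4C)[C@@H]4CC[C@@]5(C)C[C@]43CC5=O)nn2)cc1`. In this assay compound 1 gives > 20000 nM, which is a limit of the assay and not a number. In this assay compound 2 gives > 20000 nM, again a limit. In this assay compound 3 gives > 20000 nM, also a limit. Compound 3 therefore stands nowhere distinguishable from the other two: all three values sit at the limit of > 20000 nM in this assay, at which 3 of the 3 values shown sit. Among the measured compounds shown here, the only pair differing in one place is compound 1 against compound 3, and that step, a step that the two limits leave unreadable from compound 1 to compound 3, is unreadable, as both ends are limits.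

Compound 4 `Cc1ccc(-c2cn(C[C@H]3c4c(ccc(OS(=O)(=O)c5ccc(C)cc5)c4C)[C@@H]4CC[C@@]5(C)C[C@]43CC5=O)nn2)cc1` is not yet measured in this assay. It differs from compound 3 as follows: methyl in place of methoxy on an aromatic carbon. For the measured compounds named here, the single measured step bears on this change only in the weakest sense, since a methoxy entering on the aromatic carbon, from compound 1 to compound 3, left the value at the limit. No direction and no size can be read from that. For compound 4 the expected step that the limit leaves unreadable from compound 3 to compound 4 is therefore none beyond the scatter. Compound 4 is expected to give about 30000 nM in this assay, estimated between 8000 nM and 120000 nM, most likely reported again as a limit.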

Compound 4, half-maximal inhibitory concentration: > 20000 nM
Compound 4: no number, only a limit; the forecaster's own chance of this, stated with the estimate: 80%; the middle value is on the limit's open side.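

In this assay compound 4 gives > 20000 nM as a limit of the assay and not a number. No new step can be read for compound 4 against compound 3 or compound 1, as both ends of each pair are limits: the limit of > 20000 nM in this assay, at which 4 of the 4 values shown sit. The compounds shown leave open which change, if any, would give a measurable value in this assay.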